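Sulfonyl aryl exchange on the way to compound 3

The source may report more compounds than this note shows. Statements on the series, on what has been measured and on what is new or still open speak of the compounds shown alone.

Going by the values given here, in an ADME assay on a cell-free system (plasma, Mus musculus) for protein binding (on this read-out higher numbers stand for a larger free fraction and lower numbers for a smaller free fraction), compound 1 (`Cc1ccc(S(=O)(=O)[C@@]2(c3ccc(C(F)(C(F)(F)F)C(F)(F)F)cc3)CCN(C(=O)[C@H]3CC[C@H](C(=O)O)CC3)C2)cc1`) gives 0.026, the only number available so far. Going by these compounds, compound 2 (`COc1ccc(S(=O)(=O)[C@@]2(c3ccc(C(F)(C(F)(F)F)C(F)(F)F)cc3)CCN(C(=O)[C@H]3CC[C@H](C(=O)O)CC3)C2)cc1`) has no number, its result standing as "not determined" (no result reported), so its place on this scale is unknown and it cannot be compared with compound 1. Compound 3 (`Cc1cc(S(=O)(=O)[C@@]2(c3ccc(C(F)(C(F)(F)F)C(F)(F)F)cc3)CCN(C(=O)[C@H]3CC[C@H](C(=O)O)CC3)C2)ccc1F`) is the next compound to be measured. It carries 4-fluoro-3-methylphenyl in place of 4-methoxyphenyl on a sulfonyl sulfur, and the rest of the structure stays the same: 4-fluoro-3-methylphenyl in place of 4-methoxyphenyl on a sulfonyl sulfur. Among the compounds with values here, no measured step in this assay covers this exchange. The expectation is therefore a step no larger than the usual scatter, in neither direction, with compound 1 at 0.026 as the only anchor. Compound 3 is expected at 0.024, with an estimated range of 0.011 to 0.05.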

Compound 3, unbound fraction: 0.029
Compound 3: middle estimate off by 1.2-fold (0.08 log units), on the low side, within the range that was stated.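

In this assay, going by these compounds alone, the exchange on a sulfonyl sulfur can now be read for the first time, as 4-fluoro-3-methylphenyl in place of 4-methylphenyl gives a 1.1-fold higher number from compound 1 to compound 3 (0.05 log units; within the scatter) and stays within the scatter. This position therefore tolerates this change without a distinguishable shift in the read-out, at least for this pair on the shared core. No supporting data on the reason for this are available.

Going by these compounds, compound 2 has no number, so the steps to it cannot be read and the standing of 4-methoxyphenyl in this assay remains unknown. Also open, on these data alone, is whether a sulfonyl aryl bearing an amine or a carboxylic acid, or a pyridine ring in place of the phenyl ring, would give a step beyond the scatter.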